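Alkynyl-linked nucleosides: cytotoxicity notes toward compound 4

A few compounds are considered here, and "the series" means these few. Any claim that something is new, unique, unknown or untested is made for them only; others in the source may bear on it.

Compound 1 `CCCCCCCC/C=C/c1cc2cn([C@H]3C[C@H](O)[C@@H](CO)O3)c(=O)nc2o1`, compound 2 `CCCCCc1ccc(CCc2cc3cn([C@H]4C[C@H](O)[C@@H](CO)O4)c(=O)nc3o2)cc1` and compound 3 `CCCc1ccc(C#Cc2cc3cn([C@H]4C[C@H](O)[C@@H](CO)O4)c(=O)nc3o2)cc1` share one core and differ in the side chain. In an ADME assay on HEL cells (Homo sapiens) for cytotoxicity, with a stated time of 3 days (a lower number here means that less compound is tolerated, a higher number that more compound is tolerated), compound 1 reaches only a limit of the assay, >= 120000 nM. Compound 2 likewise gives a limit in this assay, >= 470000 nM. Among the measured compounds shown here, compound 3 is the one compound with a real number in this assay, 87000 nM, and so stands as the sole anchor of the series. Compound 4 `CCCCCc1ccc(C#Cc2cc3cn([C@H]4C[C@H](O)[C@@H](CO)O4)c(=O)nc3o2)cc1` differs from compound 3 by ethyl in place of hydrogen on a saturated chain carbon, three bonds along the chain from an aromatic carbon. For the measured compounds named here, no step between measured compounds is available; the step is expected to be modest, a 1.7-fold higher number from compound 3 to compound 4 (0.24 log units; within the scatter), toward more compound tolerated. Compound 4 is therefore estimated at 150000 nM, with a range from 45000 nM to 500000 nM.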

Compound 4, minimum cytotoxic concentration: 470000 nM
Compound 4: middle estimate off by 3.1-fold (0.50 log units), on the low side; the range from low to high includes it.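

In this assay, among the compounds shown here, the first readable step falls at this position: propyl to pentyl gives a 5.4-fold higher number from compound 3 to compound 4 (0.73 log units; beyond the scatter), toward more compound tolerated. For the compounds shown here, this saturated chain carbon, three bonds along the chain from an aromatic carbon, therefore responds to added ethyl in this read-out, which the earlier limits and the single number of compound 3 could not show. The number for compound 4 coincides with a figure already seen in the series as a limit: the limit of >= 470000 nM in this assay, at which 1 of the 4 values shown sits.

As far as these compounds go, whether a longer chain such as heptyl raises the number further, and how an amine or a carboxylic acid at this carbon reads, stays open.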